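The source may hold more compounds than are shown below. What is called first, only, known or untested is meant among the compounds shown, and "the series" means these compounds.

Measured compounds:
- compound 1 `Cc1nc2cc(C(=O)NCc3ccc(F)c(C4CC4)c3)nn2c(-c2cc(F)c3c(c2C)CCCO3)c1[C@H](OC(C)(C)C)C(=O)O`: > 40000 nM
- compound 2 `COc1cc(CNC(=O)c2cc3nc(C)c([C@H](OC(C)(C)C)C(=O)O)c(-c4cc(F)c5c(c4C)CCCO5)n3n2)ccc1F`: > 20000 nM
- compound 3 `Cc1nc2cc(C(=O)NCc3ccc(F)cc3O)nn2c(-c2cc(F)c3c(c2C)CCCO3)c1[C@H](OC(C)(C)C)C(=O)O`: > 40000 nM

In an ADME assay on MT2 cells (Homo sapiens) for cytotoxicity (a lower number here means that less compound is tolerated, a higher number that more compound is tolerated), compound 1 gives > 40000 nM, which is a limit of the assay and not a number. Compound 2 gives > 20000 nM, likewise only a limit. Compound 3 gives > 40000 nM, again a limit. Compound 3 thus stands at the limit of > 40000 nM in this assay, at which 2 of the 3 values shown sit, and no value in the set is a measured number; one sits at the limit of > 20000 nM in this assay, at which 1 of the 3 values shown sits.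

Every value is a limit. The three single-point steps carry no readable size: a step that the two limits leave unreadable from compound 1 to compound 2, a step that the two limits leave unreadable from compound 1 to compound 3 and a step that the two limits leave unreadable from compound 2 to compound 3 all remain unreadable. Nothing in the set shows that changing the group on the saturated chain carbon bound to the amide-type nitrogen moves cytotoxicity at all.

Compound 4 `Cc1nc2cc(C(=O)NCCC(C)C)nn2c(-c2cc(F)c3c(c2C)CCCO3)c1[C@H](OC(C)(C)C)C(=O)O` differs from compound 3 in one place: isobutyl in place of 4-fluoro-2-hydroxyphenyl on a saturated chain carbon bound to an amide-type nitrogen. The step of a number no higher from compound 3 to compound 4 (the limit leaves the size open) is expected to show no change that can be read beyond the scatter, since the bearing steps are themselves unreadable, and the most likely outcome is another limit. Compound 4 is therefore estimated to give 40000 nM in this assay, with a range from 20000 nM to 80000 nM.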

Compound 4, half-maximal cytotoxic concentration: > 40000 nM
Compound 4 gave a limit, no number; the forecaster's own chance of this, stated with the estimate: 85%; the middle value sits exactly at the limit.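

In this assay compound 4 gives > 40000 nM, a limit of the assay and not a number. The steps to compound 4 from compound 1, compound 2 and compound 3 therefore cannot be read. Still open, as far as these compounds go, is whether any group on the saturated chain carbon bound to the amide-type nitrogen moves cytotoxicity at all, since all four values shown are limits.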